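This account rests on a few compounds, and the source may have more. Where it says the series, first, only, none or still open, it means among the compounds named here.

Compound 3 `COc1cc(N2C(N)=C(C#N)C(c3ccc(C)cc3)C3=C2CC(C)(C)CC3=O)cc(OC)c1OC` stands second highest of the three compounds measured in a functional assay on Ehrlich cells (Mus musculus) for cytotoxicity, tested at 100 ug/mL (on this read-out higher numbers stand for a stronger effect at the one concentration tested and lower numbers for a weaker effect), where compound 3 gives 90%. Its nearest neighbour is compound 2 `COc1cc(N2C(N)=C(C#N)C(c3ccc(Cl)cc3Cl)C3=C2CC(C)(C)CC3=O)cc(OC)c1OC`, for which this assay reports 100%; the gap a number 10 percentage points lower from compound 2 to compound 3 (within the scatter) lies within the scatter, so the two cannot be told apart. Far below both is compound 1 `COc1ccc(C2C(C#N)=C(N)N(c3cc(OC)c(OC)c(OC)c3)C3=C2C(=O)CC(C)(C)C3)cc1`, which in this assay gives only 15%.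

The step to compound 4 `COc1cc(N2C(N)=C(C#N)C(c3cccs3)C3=C2CC(C)(C)CC3=O)cc(OC)c1OC` is thiophen-2-yl in place of 4-methylphenyl on a saturated ring carbon. Going by the values given here, two measured steps bear on it, since both alter the aryl group on that same saturated ring carbon. Going from the 4-methoxyphenyl of compound 1 to the 2,4-dichlorophenyl of compound 2 gave a number 85 percentage points higher from compound 1 to compound 2 (beyond the scatter), and from the same methoxy to methyl gave a number 75 percentage points higher from compound 1 to compound 3 (beyond the scatter); yet between 4-methylphenyl and 2,4-dichlorophenyl there was no difference beyond the scatter. Among the compounds with values here, the group at this position thus matters greatly for some exchanges and not at all for others, and no thiophen-2-yl analogue has been measured. He therefore expects compound 4 to remain in the active range but allows a wide margin, with an estimated step of a number 20 percentage points lower from compound 3 to compound 4 (beyond the scatter). His estimate for compound 4 in this assay is 70%, between 30% and 100%.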

Compound 4, a percentage reported as activity, at one concentration (the size of the read-out at that concentration, not a potency): 20%
Estimate against measurement, compound 4: 50 percentage points above; measured number outside the range, below it.
By their numbers in this assay, from the lowest: compounds 1 and 4 (each within the scatter of the next); then compounds 3 and 2 (each within the scatter of the next).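

In this assay the group on this saturated ring carbon now sorts the four compounds into two sets, and size of the aryl group alone does not decide membership: thiophen-2-yl takes the read-out down sharply from 4-methylphenyl (a number 70 percentage points lower from compound 3 to compound 4 (beyond the scatter)) and from 2,4-dichlorophenyl (a number 80 percentage points lower from compound 2 to compound 4 (beyond the scatter)), so this five-membered sulfur-bearing aromatic ring does not stand in for either of those six-membered rings. Against 4-methoxyphenyl the same exchange gives no distinguishable change (a number 5 percentage points higher from compound 1 to compound 4 (within the scatter)), which places thiophen-2-yl in one set with 4-methoxyphenyl and shows that the low read-out is not confined to the methoxy compound. No measurement here explains why these two groups fall together or why the other two stand apart.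

As far as these compounds go, whether unsubstituted phenyl, furan-2-yl or pyridin-3-yl at this carbon would join the high set or the low set remains open. Also open, from the compounds shown here alone, is whether the split survives when the aryl group on the ring nitrogen gives way to a benzyl group or an alkyl chain, and how it would look across a range of concentrations rather than at a single one.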